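This account rests on a few compounds, and the source may have more. Where it says the series, first, only, none or still open, it means among the compounds named here.

Measured compounds:
- compound 1 `NC(=O)c1c(NC(=O)c2ccccc2Cl)sc2c1CCN(Cc1ccccc1)C2`: 14500 nM
- compound 2 `NC(=O)c1c(NC(=O)c2ccccc2Cl)sc2c1CCN(C(=S)Nc1ccccc1Br)C2`: 10800 nM
- compound 3 `NC(=O)c1c(NC(=O)c2ccccc2Cl)sc2c1CCN(C(=S)Nc1c(Cl)cccc1Cl)C2`: 4020 nM

In a functional assay on MKN-74 cells (Homo sapiens) for antiproliferative activity, with a stated time of 24 h (on this read-out lower numbers stand for stronger inhibition and higher numbers for weaker inhibition), compound 2 stands second highest of the three numbers. a 1.3-fold lower number from compound 1 to compound 2 (0.13 log units; within the scatter) lies within the scatter, whereas a 2.7-fold lower number from compound 2 to compound 3 (0.43 log units; beyond the scatter) and a 3.6-fold lower number from compound 1 to compound 3 (0.56 log units; beyond the scatter) lie beyond it. Compound 4 `NC(=O)c1c(NC(=O)c2ccccc2I)sc2c1CCN(C(=S)Nc1ccccc1Br)C2` differs from compound 2 by iodo in place of chloro on an aromatic carbon. Among the compounds with values here, none of the measured steps touches that ring: all three alter the group on the amine nitrogen in the ring, so no measured step bears on this change, and no step beyond the scatter is expected in this assay. Compound 4 is therefore estimated at 9500 nM, with a range from 4000 nM to 25000 nM. The expected step is a 1.1-fold lower number from compound 2 to compound 4 (0.06 log units; within the scatter), which is expected to stay within the scatter.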

Compound 4, half-maximal inhibitory concentration: 22400 nM
For compound 4 the middle estimate is 2.4-fold (0.37 log units) below the measured one; the range from low to high includes it.
By their numbers in this assay, from the lowest: compound 3; then compounds 2, 1 and 4 (each within the scatter of the next, the first and the last beyond it).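

In this assay, the group on the amine nitrogen in the ring is no longer the only part of the structure seen to move the number: iodo in place of chloro on the aromatic carbon ortho to a large group gives a 2.1-fold higher number from compound 2 to compound 4 (0.32 log units; beyond the scatter). Thus, with the 2-bromophenyl thiourea-type group held constant, this single-atom change at the 2-chlorophenyl site has a modest effect, and the larger halogen goes with weaker inhibition. The data offer no measured explanation for this step.

Going by these compounds, whether a methoxy group or an amine at this position would behave like chloro or like iodo remains open. So does whether the same exchange would have a similar effect with the 2,6-dichlorophenyl group of compound 3.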